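Swapping the Sulfanyl Arm on an Ester Side Chain

The source may report more compounds than this note shows. Statements on the series, on what has been measured and on what is new or still open speak of the compounds shown alone.

The measured compounds:
- compound 1, `C=C1CC[C@@H]2[C@](C)(CO)[C@H](O)CC[C@@]2(C)[C@@H]1CC(Sc1ccc([N+](=O)[O-])cc1)C1=CCOC1=O`, in a functional assay on PC-3 cells (Homo sapiens) for inhibition, read by MTT assay, with a stated time of 48 h (a higher number here means a weaker inhibitor, a lower number a stronger inhibitor), compound 1 gives 17000 nM
- compound 2, `C=C1CC[C@@H]2[C@](C)(CO)[C@H](O)CC[C@@]2(C)[C@@H]1CC(Sc1ccc(F)cc1)C1=CCOC1=O`, compound 2 gives 16000 nM
- compound 3, `C=C1CC[C@@H]2[C@](C)(CO)[C@H](O)CC[C@@]2(C)[C@@H]1C/C=C1/C(=O)OC[C@H]1OC(=O)CSc1ccc([N+](=O)[O-])cc1`, compound 3 gives 17000 nM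

On these numbers compound 3 sits level with compound 1, the two together being the highest of the three, and compound 2 lies within the scatter of both, so no ordering among them can be claimed. Compound 4, `C=C1CC[C@@H]2[C@](C)(CO)[C@H](O)CC[C@@]2(C)[C@@H]1C/C=C1/C(=O)OC[C@H]1OC(=O)CCCSc1ccc(OC)cc1`, has not yet been measured in this assay. It differs from compound 3 by 2-((4-methoxyphenyl)sulfanyl)ethyl in place of (4-nitrophenyl)sulfanyl on a saturated chain carbon bound to a carbonyl carbon.

Among the measured compounds shown here, only one measured step bears on this: a 1.1-fold lower number from compound 1 to compound 2 (0.03 log units; within the scatter). That step swapped one substituent on the aromatic ring of the sulfanyl arm and produced nothing beyond the scatter. For the measured compounds named here, the change to compound 4 also swaps the ring substituent, and in addition lengthens the chain between the ester and the sulfur, for which no measured step exists. Going by the values given here, with the one relevant step flat, no movement beyond the scatter is expected. Compound 4 is therefore expected to give 17000 nM, with a range from 7000 nM to 40000 nM. This corresponds to an expected step of no change at the digits printed from compound 3 to compound 4 (within the scatter).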

Compound 4, half-maximal inhibitory concentration: 19000 nM
Estimate against measurement, compound 4: 1.1-fold (0.05 log units) below, within the range that was stated.
By their numbers in this assay, from the lowest: compounds 2, 1, 3 and 4 (each within the scatter of the next).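

A larger edit at this position still leaves the number within the scatter. On a saturated chain carbon bound to a carbonyl carbon, exchanging the ring substituent and lengthening the chain to the sulfur together give a 1.1-fold higher number from compound 3 to compound 4 (0.05 log units; within the scatter) in this assay, whereas the earlier measured step involved only a swap of ring substituent. No supporting data are available to explain why this activity stays flat.

From the compounds shown here alone, compound 4 carries both edits at once, so it remains open whether each has no effect alone or whether their effects offset one another. Also open, going by these compounds, is whether an amine or a carboxylic acid on the aromatic ring, in place of the nitro or methoxy group, would shift the number beyond the scatter.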